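The source may report more compounds than this note shows. Statements on the series, on what has been measured and on what is new or still open speak of the compounds shown alone.

Measured in a functional assay on HCT-116 cells (Homo sapiens) for antiproliferative activity, read by MTT assay, with a stated time of 72 h; a lower number here means a stronger inhibitor, a higher number a weaker inhibitor:
- compound 1 `NC1=NC2(CCOCC2)N(OCCCOc2ccccc2)C(N)=N1`: 6010 nM
- compound 2 `COc1ccc(OCCCON2C(N)=NC(N)=NC23CCOCC3)cc1`: 1500 nM

Among the measured compounds shown here, compound 1 holds the higher, weaker number of the two, and compound 2 is its only neighbour. Compound 3 `NC1=NC2(CCOCC2)N(OCCCOc2ccc(F)cc2)C(N)=N1` is compound 1 with one change: fluoro in place of hydrogen on an aromatic carbon, para to a large group.

For the measured compounds named here, one measured step bears on this: a 4.0-fold lower number from compound 1 to compound 2 (0.60 log units; beyond the scatter), for methoxy in place of hydrogen on an aromatic carbon. It involves a different group and is a single example, so it is only a loose guide. A smaller move to a lower number is expected in this assay, and it may not clear the scatter. The expected step is a 2.0-fold lower number from compound 1 to compound 3 (0.30 log units; within the scatter). For compound 3 the estimated value is 3000 nM, with an expected range of 1200 nM to 7000 nM.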

Compound 3, half-maximal inhibitory concentration: 3280 nM
Estimate against measurement, compound 3: 1.1-fold (0.04 log units) below, and the stated range covers the measured number.
By their numbers in this assay, from the lowest: compound 2; then compounds 3 and 1 (each within the scatter of the next).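

In this assay, phenoxy to 4-fluorophenoxy gives a 1.8-fold lower number from compound 1 to compound 3 (0.26 log units; within the scatter), so at this place on the ring fluoro cannot be told apart from hydrogen. Methoxy at the same place does stand apart from fluoro, with a 2.2-fold higher number from compound 2 to compound 3 (0.34 log units; beyond the scatter), so the position responds to the group placed there, and compound 2 holds the lowest number of the three. No measurement available here accounts for the gap between methoxy and fluoro.

Still open, going by these compounds, is whether the response is particular to methoxy or extends to other groups at this place, such as ethoxy, a dimethylamino group or a carboxylic acid. Also open, on these data alone, is whether methoxy would keep its standing at another place on the ring or with a longer chain linking the ring to the core.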